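A few compounds are considered here, and "the series" means these few. Any claim that something is new, unique, unknown or untested is made for them only; others in the source may bear on it.

In a functional assay on the whole organism with Rattus norvegicus as the target, at a dose of 40 mg/kg by the intraperitoneal route (on this read-out lower numbers stand for less inhibition and higher numbers for more inhibition at the one dose given (going by the name of the read-out)), three compounds have been measured so far. Compound 1 `CC(=O)Nc1c(C)nc2c(OCc3ccccc3)cccn12` gives 93% in this assay. Compound 3 `CCNc1c(C)nc2c(OCc3ccccc3)cccn12` differs from compound 1 in one place, (ethyl in place of acetyl on a nitrogen on an aromatic ring), and in this assay compound 3 gives 95%. That change made a step of a number 2 percentage points higher from compound 1 to compound 3 (within the scatter), so the two numbers cannot be told apart. Compound 2 `CC(=O)Nc1c(C)nc2c(CCc3ccccc3)cccn12` has a different core; the difference between the two cores is not broken down here. In this assay compound 2 gives 40%, the lowest of the three numbers, and its gap to each of the other two lies beyond the scatter.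

Compound 4 `CCNc1c(C)nc2c(CCc3ccccc3)cccn12` has not yet been measured. It stands to compound 2 exactly as compound 3 stands to compound 1: the change is ethyl in place of acetyl on a nitrogen on an aromatic ring, and the surroundings of that place read the same in both pairs, so this is the same change made a second time on the other core. Because the step of a number 2 percentage points higher from compound 1 to compound 3 (within the scatter) stayed within the scatter, the expected step from compound 2 to compound 4 is likewise small, a number 2 percentage points higher from compound 2 to compound 4 (within the scatter), although it rests on a single earlier instance on a different core. Compound 4 is therefore estimated at 42% in this assay, expected to fall between 25% and 62%.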

Compound 4, a percentage reported as inhibition, in the whole organism at one dose (the size of the read-out at that dose, not a potency): 78%
Compound 4: middle estimate off by 36 percentage points, on the low side; measured number outside the range, above it.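

In this assay, putting ethyl in place of acetyl on the nitrogen gives a number 38 percentage points higher from compound 2 to compound 4 (beyond the scatter), so on the core of compound 2 this one change moves the read-out by a large amount. Set beside the earlier pair, the step does not keep its size from one core to the other, and a step seen on one core is therefore a poor guide to the step on the other: the same change on two cores in this assay, a number 2 percentage points higher (within the scatter) from compound 1 to compound 3 and a number 38 percentage points higher (beyond the scatter) from compound 2 to compound 4, 36 percentage points apart, beyond the scatter of two such steps What this does not show is why the two cores behave differently, or what would happen on a third core, and the first pair may say little in any case, as compound 1 already gives 93%, close to the top of a percentage scale, which leaves that pair little room to rise.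

The compounds shown carry only acetyl or ethyl on that nitrogen, so it stays open how a longer chain such as propyl, or a plain amino group, would read on each core. Going by these compounds, each compound also has a number at a single dose only, so it stays open whether the two steps would keep their sizes at other doses.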